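This account rests on a few compounds, and the source may have more. Where it says the series, first, only, none or still open, it means among the compounds named here.

Compound 1 — `CCC(C(=O)N1CCN(c2cccc(Cl)c2)CC1)N1C(=O)CCC1=O` — 25%
Compound 2 — `CCC(C(=O)N1CCN(c2ccccc2)CC1)N1C(=O)CCC1=O` — 25%
Compound 3 — `CCC(C(=O)N1CCN(c2cccc(C)c2)CC1)N1C(=O)CCC1=O` — 0%

Of the compounds shown here, three sharing one core have been tested in a functional assay on the whole organism (strain Swiss) with Mus musculus as the target, in the maximal electroshock model, with a stated time of 2 h, at a dose of 300 mg/kg by the intraperitoneal route; a lower number here means a weaker effect, a higher number a stronger effect of the compound at the dose given. Compound 1 gives 25% and compound 2 gives 25%, two numbers that lie within the scatter of each other. Compound 3 gives 0% and has the lowest number of the three, as the steps of a number 25 percentage points lower from compound 1 to compound 3 (beyond the scatter) and a number 25 percentage points lower from compound 2 to compound 3 (beyond the scatter) show. Compound 4, `CCC(C(=O)N1CCN(c2ccccc2Cl)CC1)N1C(=O)CCC1=O`, differs from compound 3 in a single place: 2-chlorophenyl in place of 3-methylphenyl on an amine nitrogen in a ring.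

Within the data shown here, two measured steps bear on this change. The step of a number 25 percentage points lower from compound 2 to compound 3 (beyond the scatter) shows that putting a methyl on the aromatic ring lowered the number, so taking it away again would be expected to raise it. The step of no change at the digits printed from compound 1 to compound 2 (within the scatter) shows that exchanging chloro for hydrogen on the aromatic carbon made no difference beyond the scatter, though there the chloro was carried by compound 1 and not as 2-chlorophenyl. Compound 4 is therefore expected to give 20%, in a range from 0% to 50%. For compound 4 this means an expected step of a number 20 percentage points higher from compound 3 to compound 4 (beyond the scatter).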

Compound 4, a percentage reported as activity, at one dose (the size of the read-out at that dose, not a potency): 0%
For compound 4 the middle estimate is 20 percentage points above the measured one, and the stated range covers the measured number.
By their numbers in this assay, from the lowest: compounds 3 and 4 (each within the scatter of the next); then compounds 1 and 2 (each within the scatter of the next).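

For the two chlorophenyl groups, this assay gives a number 25 percentage points lower from compound 1 to compound 4 (beyond the scatter), so these groups do not read the same here. Adding a chloro group to the aromatic ring also now has a result beyond the scatter, a number 25 percentage points lower from compound 2 to compound 4 (beyond the scatter), which the earlier pair with a chloro group did not show. The exchange of 3-methylphenyl for 2-chlorophenyl gives no change at the digits printed from compound 3 to compound 4 (within the scatter), so these two groups cannot be told apart in this read-out. No measurement shown accounts for these results.

The compounds leave open how a methoxy group or a trifluoromethyl group on the aromatic ring would read in this assay. They also leave open how a pyridine ring in place of the aromatic carbon ring would read.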